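The source may report more compounds than this note shows. Statements on the series, on what has been measured and on what is new or still open speak of the compounds shown alone.

Series notes. Three compounds have numbers in a functional assay on CHO cells for antagonist activity at sphingosine 1-phosphate receptor 2 (Homo sapiens), read by fluorescence and calcium flux, with a stated time of 3 min; a lower number here means a stronger inhibitor, a higher number a weaker inhibitor. Compound 1 `Cc1cc(NNC(=O)Nc2cc(Cl)nc(Cl)c2)ncc1-c1cnn(C)c1` gives 2600 nM. Compound 2 `CCOc1cc(NC(=O)NCc2cc(C)c(-c3cn(C)nc3C(F)(F)F)nn2)cc(C#N)n1` gives 11000 nM. Compound 3 `CCOc1cc(NC(=O)NCc2cc(C)c(-c3cn(C)nc3C(F)(F)F)nn2)cc(C)n1` gives 54000 nM. Among the compounds with values here, the one single-point step measured so far, a 4.9-fold higher number from compound 2 to compound 3 (0.69 log units; beyond the scatter), runs in the direction of a weaker inhibitor. Compound 3 therefore stands at the highest number of the three, with compound 2 the nearest and compound 1 the furthest from it.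

Compound 4 `CCOc1nc(Cl)cc(NC(=O)NCc2cc(C)c(-c3cn(C)nc3C(F)(F)F)nn2)c1C` is not yet measured. It differs from compound 3 in one place: 6-chloro-2-ethoxy-3-methylpyridin-4-yl in place of 2-ethoxy-6-methylpyridin-4-yl on an amide-type nitrogen. Within the data shown here, no measured step addresses this exchange. Among the measured compounds shown here, the only measured step, from compound 2 to compound 3, concerns the same aromatic ring but swaps a different group, and compound 1 carries chlorine on its ring only together with many other differences, so its value gives no usable comparison. For the measured compounds named here, with no step bearing directly on the change, the expectation is a number for compound 4 in this assay close to that of compound 3, with no step beyond the scatter in either direction. On that basis compound 4 is estimated at 40000 nM, within a range of 9000 nM to 170000 nM. The expected step from compound 3 is a 1.4-fold lower number from compound 3 to compound 4 (0.13 log units; within the scatter).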

Compound 4, half-maximal inhibitory concentration: 8800 nM
Compound 4: middle estimate off by 4.5-fold (0.66 log units), on the high side; the measured number lies below the stated range.
By their numbers in this assay, from the lowest: compound 1; then compounds 4 and 2 (each within the scatter of the next); then compound 3.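

Notes on the pyridine on the amide-type nitrogen: in this assay, the 2-ethoxy-6-methylpyridin-4-yl group of compound 3 is not the limit for a methyl-bearing ring, as 6-chloro-2-ethoxy-3-methylpyridin-4-yl brings back a clear gain (a 6.1-fold lower number from compound 3 to compound 4 (0.79 log units; beyond the scatter)). The nitrile is also not needed to reach the level of compound 2, given that 6-chloro-2-ethoxy-3-methylpyridin-4-yl and 2-cyano-6-ethoxypyridin-4-yl read alike (a 1.3-fold lower number from compound 2 to compound 4 (0.10 log units; within the scatter)); the earlier step from nitrile to methyl alone (a 4.9-fold higher number from compound 2 to compound 3 (0.69 log units; beyond the scatter)) could not show this. No supporting data are available that would account for the gain seen with this exchange.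

The exchange adds chlorine and changes where the methyl sits in a single move, and no compound shown carries one change without the other, so the share of each in the step stays open. Also open, going by these compounds, is what an amine or a carboxylic acid would give in place of the chlorine, or a longer chain in place of the ethoxy group, on this ring.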